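The compounds below may be only part of what the source reports. "The series", "measured", "known", "first", "only" and "open" are said of these compounds alone.

Measured compounds:
- Compound 1 `Cn1cc(C2=C(c3n[nH]c4ncccc34)C(=O)NC2=O)c2ccccc21`: in a functional assay on ECa-109 cells (Homo sapiens) for antiproliferative activity, read by MTT assay, with a stated time of 48 h (on this read-out lower numbers stand for stronger inhibition and higher numbers for weaker inhibition), compound 1 gives 46100 nM.
- Compound 2 `CN(C)CCCn1nc(C2=C(c3cn(C)c4ccccc34)C(=O)NC2=O)c2cccnc21`: in this assay compound 2 gives > 100000 nM, which is a limit of the assay and not a number.
- Compound 3 `CN1CCN(CCCn2nc(C3=C(c4cn(C)c5ccccc45)C(=O)NC3=O)c3cccnc32)CC1`: in this assay compound 3 gives > 100000 nM, again a limit of the assay.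

Compound 3 thus stands at the limit noted in the limit of > 100000 nM in this assay, at which 2 of the 3 values shown sit, where two of the three values shown sit. The two chain-bearing compounds both fall away from compound 1: an at least 2.1-fold higher number from compound 1 to compound 2 (0.33 log units; beyond the scatter) and an at least 2.1-fold higher number from compound 1 to compound 3 (0.33 log units; beyond the scatter). The change of the chain end itself is unreadable: a step that the two limits leave unreadable from compound 2 to compound 3.

Compound 4 `Cn1cc(C2=C(c3nn(CCCn4ccnc4)c4ncccc34)C(=O)NC2=O)c2ccccc21` differs from compound 3 by 1H-imidazol-1-yl in place of 4-methylpiperazin-1-yl on a saturated chain carbon, three bonds along the chain from an aromatic nitrogen. For the measured compounds named here, the only step that bears on the chain end, the one from compound 2 to compound 3, gives no readable size, and both of its compounds sit at the limit. The loss on adding any chain from compound 1 is at least modest in both cases shown. No shown step supports a gain for compound 4, so the expectation is a value near or at the limit, with no step beyond the scatter expected: an at least 1.1-fold lower number from compound 3 to compound 4 (0.04 log units; that floor lies within the scatter). Compound 4 is therefore estimated at 90000 nM, expected to fall between 30000 nM and 300000 nM.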

Compound 4, half-maximal inhibitory concentration: > 100000 nM
Compound 4: a limit, no number; the forecaster's own chance of this, stated with the estimate: 60%; at least 1.1-fold (0.04 log units) between middle value and limit.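

In this assay, the 3-(1H-imidazol-1-yl)propyl chain on the aromatic nitrogen gives an at least 2.1-fold higher number from compound 1 to compound 4 (0.33 log units; beyond the scatter). The loss seen with the dimethylamino and 4-methylpiperazin-1-yl chain ends therefore also appears with a five-membered aromatic ring at the chain end, so in these three compounds it does not depend on that ring type. Compound 4 gives a limit and not a number, and the steps among compounds 2, 3 and 4 cannot be read, as all three share it: the limit of > 100000 nM in this assay, at which 3 of the 4 values shown sit.

From the compounds shown here alone, it remains open whether the chain ends differ at all, since none of compounds 2, 3 and 4 gives a number. A methyl group on that nitrogen, a shorter chain, or a chain ending in a hydroxyl or a carboxylic acid could show whether the loss follows the chain or its end.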